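Changing the Ring on the Thiocarbonyl Carbon

This account rests on a few compounds, and the source may have more. Where it says the series, first, only, none or still open, it means among the compounds named here.

In a functional assay on MGC-803 cells (Homo sapiens) for inhibition, read by CCK-8 assay, with a stated time of 48 h (a higher number here means a weaker inhibitor, a lower number a stronger inhibitor), compound 1 (`CCN1CCN(C(=S)SCC(=O)N(Cc2ccc(OC)cc2)c2cc(OC)c(OC)c(OC)c2)CC1`) gives 9890 nM, compound 2 (`COc1ccc(CN(C(=O)CSC(=S)N2CCN(C(C)=O)CC2)c2cc(OC)c(OC)c(OC)c2)cc1`) gives 480 nM and compound 3 (`COc1ccc(CN(C(=O)CSC(=S)N2CCOCC2)c2cc(OC)c(OC)c(OC)c2)cc1`) gives 2370 nM. Compound 3 therefore stands second highest of the three numbers, beyond the scatter from both others. Compound 4 (`COc1ccc(CN(C(=O)CSC(=S)N2CCCC2)c2cc(OC)c(OC)c(OC)c2)cc1`) carries pyrrolidin-1-yl in place of morpholin-4-yl on a thiocarbonyl carbon. Two measured steps change this same place, a 4.2-fold lower number from compound 1 to compound 3 (0.62 log units; beyond the scatter) and a 4.9-fold higher number from compound 2 to compound 3 (0.69 log units; beyond the scatter). Both are modest, but they run in opposite directions, and neither involves a five-membered ring. No direction can be read from them, so no shift beyond the scatter is expected in this assay. The estimated step is a 1.3-fold lower number from compound 3 to compound 4 (0.12 log units; within the scatter). For compound 4 the expected value is 1800 nM, with an estimated range of 500 nM to 6500 nM.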

Compound 4, half-maximal inhibitory concentration: > 20000 nM
Compound 4: no number, only a limit (the forecaster's own chance of this, stated with the estimate: 3%); middle value at least 11-fold (1.04 log units) from the limit.
By their numbers in this assay, from the lowest: compound 2; then compound 3; then compound 1. At a limit, above all of these: compound 4.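

In this assay compound 4 gives only a limit, not a number: the limit of > 20000 nM in this assay, at which 1 of the 4 values shown sits. For the compounds shown here, at this place on a thiocarbonyl carbon, pyrrolidin-1-yl therefore weakens the series clearly, with an at least 8.4-fold higher number from compound 3 to compound 4 (0.92 log units; beyond the scatter) and an at least 41-fold higher number from compound 2 to compound 4 (1.61 log units; beyond the scatter), so a change of ring here can cost more than the earlier compounds showed. The remaining step, an at least 2.0-fold higher number from compound 1 to compound 4 (0.30 log units; that floor lies within the scatter), does not separate compound 4 from compound 1. From the compounds shown here alone, whether a piperidin-1-yl ring or an open-chain diethylamino group on this carbon would behave like pyrrolidin-1-yl stays open. Going by these compounds, how far the true value of compound 4 lies past its limit also stays open.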